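Methyl on the fused ring of the amino thiadiazole chromenone

The source may hold more compounds than are shown below. What is called first, only, known or untested is meant among the compounds shown, and "the series" means these compounds.

Compound 2, `Nc1nnc(SCc2cc(=O)c3ccccc3o2)s1`, is the reference. In a functional assay on MDA-MB-435S cells (Homo sapiens) for cytotoxicity, read by MTT assay, with a stated time of 72 h (on this read-out lower numbers stand for stronger inhibition and higher numbers for weaker inhibition), compound 2 gives only a limit of the assay, > 25000 nM, and no number. Its neighbour compound 1, `Cc1nnc(SCc2cc(=O)c3ccccc3o2)s1`, shares the core and carries a methyl where compound 2 carries an amino. In this assay compound 1 also gives only a limit, > 25000 nM. The step that the two limits leave unreadable from compound 1 to compound 2 is therefore not readable in size; both values sit at the same point, (the limit of > 25000 nM in this assay, at which 2 of the 2 values shown sit).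

Compound 3, `Cc1ccc2oc(CSc3nnc(N)s3)cc(=O)c2c1`, differs from compound 2 by methyl in place of hydrogen on an aromatic carbon. Among the compounds with values here, no measured step touches the fused ring, so nothing among the measured pairs bears directly on this change, and the one measured step is itself unreadable. With both known compounds at the limit, a methyl on the fused ring is not expected to carry compound 3 into a readable range. The estimated value for compound 3 is 30000 nM, spanning 8000 nM to 120000 nM, which corresponds to an expected step that the limit leaves unreadable from compound 2 to compound 3, most likely again reported only as a limit.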

Compound 3, half-maximal inhibitory concentration: > 25000 nM
Compound 3 ended at the assay's limit; the forecaster's own chance of this, stated with the estimate: 75%; the middle value is on the limit's open side.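

In this assay compound 3 gives > 25000 nM, again a limit of the assay and not a number. No size can be read for the step between compound 2 and compound 3, and all values shown coincide: the limit of > 25000 nM in this assay, at which 3 of the 3 values shown sit.

The compounds shown leave open whether any change on the shared core gives a readable value in this assay.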